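A few compounds are considered here, and "the series" means these few. Any claim that something is new, unique, unknown or untested is made for them only; others in the source may bear on it.

The series shares the core of compound 1 `Nc1ncnc2c1ccn2-c1ccc(NC(=O)Nc2ccc(Cl)c(C(F)(F)F)c2)cc1`, which in a functional assay on A375P cells (Homo sapiens) for antiproliferative activity, read by MTT assay, with a stated time of 24 h (on this read-out lower numbers stand for stronger inhibition and higher numbers for weaker inhibition), gives 8100 nM. Compound 2 `CC(=O)Nc1ncnc2c1ccn2-c1ccc(NC(=O)Nc2ccc(Cl)c(C(F)(F)F)c2)cc1` carries the acetyl; in this assay compound 2 returns only a limit, > 10000 nM, and so stands at the top edge of the numbers shown (the limit of > 10000 nM in this assay, at which 1 of the 3 values shown sits). Within the data shown here, the one single-point step, an at least 1.2-fold higher number from compound 1 to compound 2 (0.09 log units; that floor lies within the scatter), is a floor within the scatter and concerns the acetyl in place of hydrogen on a nitrogen on an aromatic ring. Compound 3 `O=C(Nc1ccc(-n2ccc3c(NC(=O)c4ccccc4)ncnc32)cc1)c1cccc(C(F)(F)F)c1` gives 4700 nM in this assay; it is an amide rather than a urea and differs from the others in several places. Compound 4 `CC(=O)Nc1ncnc2c1ccn2-c1ccc(NC(=O)Nc2cccc(Cl)c2Cl)cc1` keeps the acetyl of compound 2 and changes the aryl group: 2,3-dichlorophenyl in place of 4-chloro-3-(trifluoromethyl)phenyl on an amide-type nitrogen. Among the measured compounds shown here, no measured pair varies this aryl group, so an at least 1.2-fold higher number from compound 1 to compound 2 (0.09 log units; that floor lies within the scatter) does not bear on the change and the expectation rests on compound 2 sitting at the limit. From compound 2 to compound 4 the expected step is a step that the limit leaves unreadable from compound 2 to compound 4, with no direction beyond the scatter claimed. Compound 4 is estimated at 12000 nM, between 4000 nM and 40000 nM, and in this assay compound 4 may well again return only a limit.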

Compound 4, half-maximal inhibitory concentration: > 10000 nM
Compound 4 was reported as a limit; the forecaster's own chance of this, stated with the estimate: 60%; the middle value does not contradict the limit.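

In this assay compound 4 returns > 10000 nM, which is a limit. Among these compounds, with compound 2 also at a limit, no step between compound 2 and compound 4 can be read. As far as these compounds go, how 2,3-dichlorophenyl and 4-chloro-3-(trifluoromethyl)phenyl compare on the acetyl series stays open.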